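The source may hold more compounds than are shown below. What is called first, only, known or untested is meant among the compounds shown, and "the series" means these compounds.

Measured so far:

Compound 1, `O=C(C1CCN(C(=O)C(F)(F)F)CC1)N1N=CCC1c1ccccc1`, gives 0.483 h in an ADME assay on microsomes (Rattus norvegicus) for metabolic stability; a higher number here means that the compound lasts longer, a lower number that the compound disappears faster.
Compound 2, `O=C(C1CCOCC1)N1N=CCC1c1ccccc1`, gives > 1.5 h in this assay, which is a limit of the assay and not a number.
Compound 3, `O=C(C1CCC1)N1N=CCC1c1ccccc1`, gives 0.583 h in this assay.

Compound 3 and compound 1 sit within the usual scatter of each other, so no order between them can be read from these two numbers. Compound 2 only reaches the limit (the limit of > 1.5 h in this assay, at which 1 of the 3 values shown sits).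

The piece follows the step from compound 3 to compound 4, `CC(C)C(=O)N1N=CCC1c1ccccc1`, which has not yet been measured in this assay. The change is isopropyl in place of cyclobutyl on a carbonyl carbon.

Among the compounds with values here, only one measured step exists on the same carbonyl carbon: an at least 2.5-fold lower number from compound 2 to compound 3 (0.41 log units; beyond the scatter). That step swapped a ring with an oxygen for a plain carbon ring, whereas the step to compound 4 swaps one all-carbon group for a smaller all-carbon group with no ring. Within the data shown here, no measured step covers exactly this kind of change, so the expectation is a small step, in no clear direction, most likely staying within the scatter.

Compound 4 is therefore estimated at about 0.55 h, with a range from 0.3 h to 1 h.

This estimate means a step of a 1.1-fold lower number from compound 3 to compound 4 (0.03 log units; within the scatter), which is expected to be within the scatter.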

Compound 4, half-life: 1.33 h
The estimate for compound 4 lay 2.4-fold (0.38 log units) below the measured number; the whole stated range lies below it.
By their numbers in this assay, from the lowest: compounds 1 and 3 (each within the scatter of the next); then compound 4. At a limit, above all of these: compound 2.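

Within the data shown here, until now, the only step read at this carbonyl carbon had put cyclobutyl in place of oxan-4-yl, a ring with an oxygen, but here one all-carbon group replaces another and the number still moves in this assay, with a 2.3-fold higher number from compound 3 to compound 4 (0.36 log units; beyond the scatter). The isopropyl group thus brings the number close to that of the oxygen-bearing compound, with an at least 1.1-fold lower number from compound 2 to compound 4 (0.05 log units; that floor lies within the scatter), but this floor shows no clear gap and cannot fix how far apart the two compounds really are. Compound 2 stands at a limit of the assay, which is not a number: the limit of > 1.5 h in this assay, at which 1 of the 4 values shown sits.

The compounds shown do not tell why cyclobutyl gives the lower number, nor whether the loss of the ring or the change in size counts more, as this one step changes both together. Going by these compounds, it also remains open whether a longer chain or an amine on this carbonyl carbon would keep the higher number that isopropyl gives or fall back towards that of cyclobutyl.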